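The compounds below may be only part of what the source reports. "The series", "measured", "known", "first", "only" and "open" are said of these compounds alone.

Working notes on the series. In a functional assay on HCT-116 cells (Homo sapiens) for antiproliferative activity, read by MTT assay, with a stated time of 72 h (a lower number here means a stronger inhibitor, a higher number a weaker inhibitor), compound 3 (`CC(C)N1C(=O)COc2ccc(-c3cnc(Cl)c(NS(=O)(=O)c4ccc(F)cc4)c3)cc21`) gives 18900 nM and compound 1 (`COc1ncc(-c2ccc3c(c2)N(c2ccc(C)cc2)C(=O)CO3)cc1NS(=O)(=O)c1ccc(F)cc1`) gives 22700 nM, two values within the scatter of each other. Compound 2 (`O=C1COc2ccc(-c3cnc(Cl)c(NS(=O)(=O)c4ccc(F)cc4)c3)cc2N1C1CCCCC1`) gives only a limit of the assay, > 40000 nM. Within the data shown here, compound 3 therefore stands with compound 1 as one of only two compounds with a measured number, and neither can be placed ahead of the other.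

Compound 4 (`Cc1ccc(N2C(=O)COc3ccc(-c4cnc(Cl)c(NS(=O)(=O)c5ccc(F)cc5)c4)cc32)cc1`) carries 4-methylphenyl in place of isopropyl on the amide-type nitrogen in a ring: 4-methylphenyl in place of isopropyl on an amide-type nitrogen in a ring.

Among the measured compounds shown here, one measured step bears on this change, the exchange of cyclohexyl for isopropyl at that same nitrogen, which runs an at least 2.1-fold lower number from compound 2 to compound 3 (0.32 log units; beyond the scatter). There, the compound with the ring-bearing group sits at the limit. Compound 1, which has the same 4-methylphenyl on that nitrogen, gives 22700 nM, a measured number. Taken together, these point to a small move towards a higher number in this assay, possibly no larger than the scatter, and not to a complete loss of activity.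

The expected step runs a 1.3-fold higher number from compound 3 to compound 4 (0.12 log units; within the scatter). For compound 4, the estimated value is 25000 nM, with an expected range of 12000 nM to 40000 nM.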

Compound 4, half-maximal inhibitory concentration: 34300 nM
The estimate for compound 4 lay 1.4-fold (0.14 log units) below the measured number; the measured number falls inside the stated range.
By their numbers in this assay, from the lowest: compounds 3, 1 and 4 (each within the scatter of the next). At a limit, above all of these: compound 2.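

In this assay, the step from isopropyl to 4-methylphenyl on the amide-type nitrogen in a ring runs a 1.8-fold higher number from compound 3 to compound 4 (0.26 log units; within the scatter), so these two groups cannot be told apart at this position with chloro in the core. Chloro in place of methoxy on an aromatic carbon, with 4-methylphenyl held on the nitrogen, gives the first reading of that exchange, a 1.5-fold higher number from compound 1 to compound 4 (0.18 log units; within the scatter), and this too does not separate the two compounds. The step from cyclohexyl to 4-methylphenyl runs an at least 1.1-fold lower number from compound 2 to compound 4 (0.06 log units; that floor lies within the scatter), a floor that does not set compound 4 apart from compound 2, whose value is only a limit of the assay: the limit of > 40000 nM in this assay, at which 1 of the 4 values shown sits.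

The compounds shown leave open whether any group on this nitrogen can move the number beyond the scatter towards a lower value, as a chain ending in an amine or a carboxylic acid might or might not do. Also open, from the compounds shown here alone, is whether the exchange of chloro and methoxy reads the same with isopropyl on that nitrogen.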